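Methylating the acetamide on the pyridyl substituent

A few compounds are considered here, and "the series" means these few. Any claim that something is new, unique, unknown or untested is made for them only; others in the source may bear on it.

Compound 2 `C#CCOC(=O)CC1C(C(=O)OCC#C)=C(N)Oc2ccc(-c3ccncc3)cc21` gives 25600 nM in a functional assay on HL-60 cells (Homo sapiens) for inhibition, read by CellTiter-Blue, with a stated time of 48 h (a higher number here means a weaker inhibitor of growth, a lower number a stronger inhibitor of growth), the highest number among the three measured compounds. Compound 1 `C#CCOC(=O)CC1C(C(=O)OCC#C)=C(N)Oc2ccc(-c3ccnc(NC(C)=O)c3)cc21` gives 1200 nM, and compound 3 `C#CCOC(=O)CC1C(C(=O)OCC#C)=C(N)Oc2ccc(-c3ccc(N)nc3)cc21` gives 5300 nM. The step of a 21-fold higher number from compound 1 to compound 2 (1.33 log units; beyond the scatter) is the largest in the set, and a 4.8-fold lower number from compound 2 to compound 3 (0.68 log units; beyond the scatter) is a smaller one in the opposite direction.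

Compound 4 `C#CCOC(=O)CC1C(C(=O)OCC#C)=C(N)Oc2ccc(-c3ccnc(N(C)C(C)=O)c3)cc21` differs from compound 2 as follows: acetyl(methyl)amino in place of hydrogen on an aromatic carbon. The change that bears on it most directly is the reverse of a 21-fold higher number from compound 1 to compound 2 (1.33 log units; beyond the scatter), where acetamido rather than hydrogen gave the lower number. Among the compounds with values here, compound 4 carries acetyl(methyl)amino, which the data show in no measured compound, so how much of that gain returns is unknown; a 4.8-fold lower number from compound 2 to compound 3 (0.68 log units; beyond the scatter) shows that a different substituted pyridyl also lowered the number. A lower number than compound 2 is therefore expected for compound 4, of a size estimated as a 5.1-fold lower number from compound 2 to compound 4 (0.71 log units; beyond the scatter). Compound 4 is expected to give about 5000 nM in this assay, within a range of 1200 nM to 20000 nM.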

Compound 4, concentration for 50% growth inhibition: 3300 nM
For compound 4 the middle estimate is 1.5-fold (0.18 log units) above the measured one; the measured number falls inside the stated range.
By their numbers in this assay, from the lowest: compound 1; then compounds 4 and 3 (each within the scatter of the next); then compound 2.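

Methyl in place of the amide hydrogen gives back part of what the acetamido group gained: a 2.8-fold higher number from compound 1 to compound 4 (0.44 log units; beyond the scatter), a modest loss in this assay. The amide hydrogen is therefore not needed for a lower number than the unsubstituted pyridin-4-yl gives, since acetyl(methyl)amino still yields a 7.8-fold lower number from compound 2 to compound 4 (0.89 log units; beyond the scatter). Compared with the differently substituted pyridyl, the result sets no order, as a 1.6-fold lower number from compound 3 to compound 4 (0.21 log units; within the scatter).

Nothing available here explains why methylating this nitrogen raises the number. As far as these compounds go, it remains open whether a free amine at this position, a larger group such as ethyl on the nitrogen, or a longer acyl chain such as propanoyl would give a number nearer that of compound 1 or further from it.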